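The source may hold more compounds than are shown below. What is called first, only, known or untested is meant among the compounds shown, and "the series" means these compounds.

Compound 1 `Cc1ccc(-c2cnn3c(NCc4ccccn4)cc(C)nc23)cc1`: < 5000 nM in a physicochemical assay for solubility, read by HPLC, using the shake flask method, measured as kinetic solubility, with a stated time of 2 h, at pH 7.4; a lower number here means a less soluble compound, a higher number a more soluble compound.
Compound 2 `Cc1cc(NCc2nccs2)n2nc(C)c(-c3ccccc3)c2n1`: 108000 nM in this assay.

Compound 1 stands at a limit of this assay, as the limit of < 5000 nM in this assay, at which 1 of the 2 values shown sits, records, so its solubility is known only as a limit, not as a number. Compound 2 gives 108000 nM in this assay. Compound 3 `Cc1cc(NCc2ccccn2)n2ncc(-c3cccc(Cl)c3)c2n1` differs from compound 1 by 3-chlorophenyl in place of 4-methylphenyl on an aromatic carbon. Among the compounds with values here, no measured pair shares this change, so nothing in the data sizes it. Compound 3 is expected to stay close to compound 1, the estimated step being a step that the limit leaves unreadable from compound 1 to compound 3, not beyond the scatter. Compound 3 is estimated at 3000 nM, within 1000 nM to 10000 nM.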

Compound 3, solubility: < 5000 nM
Compound 3 gave a limit, no number; the forecaster's own chance of this, stated with the estimate: 60%; the middle value lies beyond the limit too.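

No step can be read from compound 1 to compound 3, since each is recorded only as a limit: the limit of < 5000 nM in this assay, at which 2 of the 3 values shown sit. Still open, going by these compounds, is how 3-chlorophenyl in place of 4-methylphenyl changes the solubility of the shared core.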